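Replacing Carboxy with Hydrogen on Compound 3

The source may report more compounds than this note shows. Statements on the series, on what has been measured and on what is new or still open speak of the compounds shown alone.

In an ADME assay on microsomes from liver (Mus musculus) for metabolic stability (a higher number here means faster removal of the compound, a lower number slower removal), compound 1 (`O=C(O)Cn1nc(Cc2nc3cc(Cl)c(OCC(F)F)cc3[nH]2)c2ccccc2c1=O`) gives < 56.7 mL/min/kg which is a limit and not a number. Compound 2 (`COc1cc(OC)c(NC(=O)Cn2nc(CC(=O)O)c3ccccc32)cc1Cl`) gives < 55 mL/min/kg which is also a limit. Compound 3 (`COc1cc(OC)c(NC(=O)Cc2cn(CC(=O)O)c3ccccc23)cc1Cl`) gives < 60 mL/min/kg which is likewise a limit, so it stands with no measured number, as do the other two compounds.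

Compound 4 (`COc1cc(OC)c(NC(=O)Cc2cn(C)c3ccccc23)cc1Cl`) differs from compound 3 in one place: hydrogen in place of carboxy on a saturated chain carbon bound to an aromatic nitrogen with hydrogen in place of carboxy on a saturated chain carbon bound to an aromatic nitrogen, so carboxymethyl becomes methyl. For the measured compounds named here, no measured pair of compounds shows this change. The expectation therefore starts from compound 3 and its limit of < 60 mL/min/kg alone. A rise in clearance beyond the scatter is expected in this assay as the carboxy group leaves. The expected step is an at least 3.0-fold higher number from compound 3 to compound 4 (0.47 log units; beyond the scatter) as an estimate only. For compound 4 the estimate is 180 mL/min/kg with an expected range from 65 mL/min/kg to 420 mL/min/kg until the measurement arrives.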

Compound 4, clearance: 4050 mL/min/kg
Compound 4: middle estimate off by 23-fold (1.35 log units), on the low side, outside the stated range (above it).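

For the compounds shown here, on a saturated chain carbon bound to an aromatic nitrogen, replacing carboxy with hydrogen gives the first step that can be read in this assay, and it is large: an at least 67-fold higher number from compound 3 to compound 4 (1.82 log units; beyond the scatter). Going by these compounds alone, compound 4 is the only one of the four compounds with a measured number and the only one without carboxy, whereas compounds 1, 2 and 3 all stand at limits. The true size of the step remains unknown because compound 3 gives only a limit: the limit of < 60 mL/min/kg in this assay, at which 1 of the 4 values shown sits.

The compounds shown leave open where this assay would place an amine, or a longer chain ending in a carboxylic acid, at this position. They also leave open whether removing carboxy from the cores of compound 1 and compound 2 would bring a rise of similar size.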